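Removing the bromine: from compound 3 to compound 4

A few compounds are considered here, and "the series" means these few. Any claim that something is new, unique, unknown or untested is made for them only; others in the source may bear on it.

Of the compounds shown here, three have been tested in a functional assay on THP-1 cells (Homo sapiens) for inhibition, read by sulforhodamine B assay, tested at 100 uM; on this read-out higher numbers stand for more inhibition of growth at the one concentration tested and lower numbers for less inhibition of growth. Compound 1 `CC(=O)N1N=C(c2ccc(OCc3cn(Cc4ccc([N+](=O)[O-])cc4)nn3)cc2)CC1c1ccccc1` gives 22% in this assay. Compound 2 `COc1cc(C2CC(c3ccc([N+](=O)[O-])cc3)=NN2C(C)=O)ccc1OCc1cn(Cc2ccc([N+](=O)[O-])cc2)nn1` gives 59%, and compound 3 `COc1cc(C2CC(c3ccc(Br)cc3)=NN2C(C)=O)ccc1OCc1cn(Cc2ccc([N+](=O)[O-])cc2)nn1` gives 23%. On these numbers compound 3 stands second of three: its value and that of compound 1 lie within the usual scatter of each other, while compound 2 sits well above both.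

Among the measured compounds shown here, the only single-point step measured so far is a number 36 percentage points lower from compound 2 to compound 3 (beyond the scatter), a large drop when the nitro group is replaced by bromo. Compound 4 `COc1cc(C2CC(c3ccccc3)=NN2C(C)=O)ccc1OCc1cn(Cc2ccc([N+](=O)[O-])cc2)nn1` takes the change one stage further: hydrogen in place of bromo on an aromatic carbon. For the measured compounds named here, no measured step covers exactly this exchange. The closest hint is compound 1, whose aromatic ring at the same end of the molecule carries no substituent at all, and whose value in this assay is indistinguishable from that of compound 3 within the scatter; compound 1 differs from compound 4 elsewhere, so it only shows what an unsubstituted ring can give here.

The expectation is therefore no step beyond the scatter, a number 1 percentage points lower from compound 3 to compound 4 (within the scatter). Compound 4 is estimated at 22%, within a range from 10% to 36%.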

Compound 4, percent growth inhibition at one concentration: 10%
Compound 4: middle estimate off by 12 percentage points, on the high side; the range from low to high includes it.
By their numbers in this assay, from the lowest: compound 4; then compounds 1 and 3 (each within the scatter of the next); then compound 2.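

In this assay, bromo turns out to be more than a neutral stand-in on this aromatic carbon: there is a number 13 percentage points lower from compound 3 to compound 4 (beyond the scatter) when it gives way to hydrogen, so going from 4-bromophenyl to phenyl still costs growth inhibition. Among the compounds shown here, until now, the only step at this place was the drop from nitro to bromo, which could not show whether bromo counted for anything compared with an empty position. Set against the nitro compound, the whole exchange is a number 49 percentage points lower from compound 2 to compound 4 (beyond the scatter) and the larger share of it lies in the nitro-to-bromo part, so among compounds 2, 3 and 4 the numbers fall in the order nitro, bromo, hydrogen, with a clear gap at each stage, but nothing at hand explains why the steps have these sizes.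

Going by these compounds, three groups at one place make only a short series, so it remains open where a chloro, a methyl, an amine or a carboxylic acid on this ring would fall in that order. On these data alone, it also remains open whether nitro would keep its lead at another carbon of the same ring, or whether its value depends on this exact place.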